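This account rests on a few compounds, and the source may have more. Where it says the series, first, only, none or still open, it means among the compounds named here.

The study measured three compounds in an ADME assay on HEp-2 cells (Homo sapiens) for cytotoxicity, read by MTT assay, with a stated time of 72 h; on this read-out higher numbers stand for weaker inhibition and lower numbers for stronger inhibition. Compound 1 `COc1ccc(C2=C(c3cc(OC)c(OC)c(OC)c3)C(=O)CC2C)cc1C(=O)O`, compound 2 `COc1ccc(C2=C(c3cc(OC)c(OC)c(OC)c3)C(=O)CC2O[SiH2]C(C)(C)C)cc1` and compound 3 `C=CCOc1cc(C2=C(c3cc(OC)c(OC)c(OC)c3)C(=O)C(O)C2)ccc1OC` rest on the shared core and differ in their substituents. In this assay compound 1 gives > 100 ug/mL, which is a limit of the assay and not a number. Compound 2 gives > 100 ug/mL, again a limit. Compound 3 gives > 100 ug/mL, also a limit. Compound 3 therefore stands exactly where the other two stand, at the limit of > 100 ug/mL in this assay, at which 3 of the 3 values shown sit, and no order among the three can be read from these values. Compound 4 `COc1ccc(C2=C(c3cc(OC)c(OC)c(OC)c3)C(=O)C(O)C2)cc1NC(=O)c1ccccc1` has not been measured; it differs from compound 3 by benzamido in place of allyloxy on an aromatic carbon. Going by the values given here, no measured pair ties a single change to a shift in this assay, and every measured value sits at the same limit, so no step beyond the scatter is expected from compound 3 to compound 4. The expected step that the limit leaves unreadable from compound 3 to compound 4 expresses this. Compound 4 is estimated to give 120 ug/mL in this assay, with a range from 50 ug/mL to 300 ug/mL.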

Compound 4, half-maximal inhibitory concentration: > 100 ug/mL
Compound 4: a limit, no number; the forecaster's own chance of this, stated with the estimate: 75%; the middle value lies beyond the limit too.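

No step can be read from compound 3 to compound 4, as each gives a limit of the assay and not a number: the limit of > 100 ug/mL in this assay, at which 4 of the 4 values shown sit. The compounds shown leave open whether benzamido and allyloxy differ at all in this assay, and whether any of the four compounds differs from another.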